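Changing the Halogenated Benzyl Group: Expected Cell Tolerance

The source may hold more compounds than are shown below. What is called first, only, known or untested is meant among the compounds shown, and "the series" means these compounds.

Compound 1, `O=C1N(Cc2ccccc2Br)c2cccn2S(=O)(=O)N1Cc1cccc(F)c1`, in an ADME assay on MT4 cells (Homo sapiens) for cytotoxicity, read by MTT assay, with a stated time of 5 days (a lower number here means that less compound is tolerated, a higher number that more compound is tolerated), gives only a limit of the assay, > 269000 nM.
Compound 2, `O=C1N(Cc2ccccc2Br)c2cccn2S(=O)(=O)N1Cc1ccccc1`, in this assay gives 226000 nM.
Compound 3, `O=C1N(Cc2ccc(Cl)cc2Cl)c2cccn2S(=O)(=O)N1Cc1cccc(Br)c1`, in this assay gives only a limit of the assay, > 243000 nM.

Among the compounds with values here, compound 2 stands as the only compound of the three that yields an actual number in this assay; the other two reach the assay limit, as the limit of > 243000 nM in this assay, at which 1 of the 3 values shown sits, and the limit of > 269000 nM in this assay, at which 1 of the 3 values shown sits, record. Within the data shown here, the single measured step, an at least 1.1-fold lower number from compound 1 to compound 2 (0.07 log units; that floor lies within the scatter), lies within the usual scatter and concerns the other benzyl group, not the one changed here.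

Compound 4, `O=C1N(Cc2ccc(F)cc2)c2cccn2S(=O)(=O)N1Cc1ccccc1`, differs from compound 2 in one place: 4-fluorophenyl in place of 2-bromophenyl on a saturated chain carbon bound to an amide-type nitrogen in a ring. Among the measured compounds shown here, no measured step covers this exchange. What the data show is that three compounds with differing benzyl groups are all tolerated at high concentration, so for compound 4 no step beyond the scatter is expected in this assay, as the estimated step of a 1.0-fold higher number from compound 2 to compound 4 (0.01 log units; within the scatter) expresses. Compound 4 is therefore estimated at 230000 nM, with a range from 100000 nM to 500000 nM, and it may well register only as a limit of the assay.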

Compound 4, half-maximal cytotoxic concentration: 150000 nM
Beside the measured number, compound 4's estimate is 1.5-fold (0.19 log units) above it; the measured number falls inside the stated range.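

In this assay, moving from 2-bromobenzyl to 4-fluorobenzyl changes both the halogen and where it sits, and this exchange gives a 1.5-fold lower number from compound 2 to compound 4 (0.18 log units; within the scatter), so this double change leaves cell tolerance unresolved from that of compound 2. Within the data shown here, both compounds return actual numbers rather than limits, which makes this the first direct reading of a change to this benzyl group. Nothing in the data offers an explanation for the size of this step.

With the halogen and its place changed together, the compounds shown cannot separate the contribution of each. Going by these compounds, every group at this place is a halogenated benzyl, so it remains open how tolerance would respond to an amine or a carboxylic acid on the ring, or to a longer chain.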